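Nitrogen substituent swap on the shared core of compound 2

This account rests on a few compounds, and the source may have more. Where it says the series, first, only, none or still open, it means among the compounds named here.

Compound 2 `C/C(=C\C(=O)Nc1ccccc1OCCCC(=O)O)c1ccc2c(ccn2C(C(C)C)C(C)C)c1` and compound 1 `CCCCCC(CCCCC)n1ccc2cc(/C(C)=C/C(=O)Nc3ccccc3OCCCC(=O)O)ccc21` share one core and differ only in the group on the aromatic nitrogen. In an assay on Prostate gland for inhibition of steroid 5-alpha-reductase (Rattus norvegicus) (on this read-out higher numbers stand for weaker inhibition and lower numbers for stronger inhibition), compound 2 gives 14 nM, and compound 1 gives 25 nM; the step of a 1.8-fold lower number from compound 1 to compound 2 (0.25 log units; within the scatter) shows the two numbers sit within the scatter of each other, so compound 2 is not separated from compound 1 on this read-out.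

Compound 3 `C/C(=C\C(=O)Nc1ccccc1OCCCC(=O)O)c1ccc2c(ccn2C(CC(C)C)c2ccccc2)c1` changes the same place: 3-methyl-1-phenylbutyl in place of 1-isopropyl-2-methylpropyl on an aromatic nitrogen. Going by the values given here, the one measured step that bears on this, a 1.8-fold lower number from compound 1 to compound 2 (0.25 log units; within the scatter), exchanged two seven-carbon branched chains at the nitrogen without a step beyond the scatter. Among the compounds with values here, no measured pair shows an aromatic ring entering at this position, so the effect of the ring is untested. The expectation for compound 3 is therefore a step of a 1.1-fold higher number from compound 2 to compound 3 (0.03 log units; within the scatter), none beyond the scatter, with a wider range to reflect the untested ring. Compound 3 is estimated at 15 nM, between 5 nM and 45 nM.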

Compound 3, half-maximal inhibitory concentration: 6.3 nM
Compound 3: the middle estimate sits 2.4-fold (0.38 log units) above what was measured, and the stated range covers the measured number.
By their numbers in this assay, from the lowest: compound 3; then compounds 2 and 1 (each within the scatter of the next).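

At the aromatic nitrogen, 3-methyl-1-phenylbutyl gives the only steps beyond the scatter among these compounds in this assay, with a 2.2-fold lower number from compound 2 to compound 3 (0.35 log units; beyond the scatter) and a 4.0-fold lower number from compound 1 to compound 3 (0.60 log units; beyond the scatter), both modest. The exchange between the two branched chains without a ring stayed within the scatter, so this position is now seen to respond to the group it carries, and the lower number goes with the group that brings a six-membered aromatic ring of carbon only. Nothing measured here accounts for the lower number.

The ring and the added heavy atoms enter together in one change, so the share of each cannot be separated. On these data alone, whether a benzyl group on the nitrogen, or a cyclohexyl ring in place of the phenyl ring, would keep the lower number remains open.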